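Piperazine Substituent Exchange in a Cytotoxic Triazine Series

The compounds below may be only part of what the source reports. "The series", "measured", "known", "first", "only" and "open" are said of these compounds alone.

Compound 3 `N#Cc1ccc(Nc2nc(Oc3ccnc4ccccc34)nc(N3CCN(c4cccc(C(F)(F)F)c4)CC3)n2)cc1C(F)(F)F` carries a 3-(trifluoromethyl)phenyl on an amine nitrogen in a ring. Going by the values given here, in a functional assay on DU-145 cells (Homo sapiens) for cytotoxicity, read by sulforhodamine B assay, with a stated time of 48 h (a higher number here means a weaker inhibitor of growth, a lower number a stronger inhibitor of growth), compound 3 gives 38700 nM, the lowest of the two numbers known in this set. Compound 1 `N#Cc1ccc(Nc2nc(Oc3ccnc4ccccc34)nc(N3CCN(c4ccccn4)CC3)n2)cc1C(F)(F)F` bears a pyridin-2-yl on that same ring nitrogen, and in this assay compound 1 gives 85900 nM. Among the compounds with values here, the single measured step between these two is a 2.2-fold lower number from compound 1 to compound 3 (0.35 log units; beyond the scatter). Compound 2 `N#Cc1ccc(Nc2nc(Oc3ccnc4ccccc34)nc(N3CCN(C(c4ccccc4)c4ccc(Cl)cc4)CC3)n2)cc1C(F)(F)F` places a larger benzylic group on the same nitrogen; in this assay compound 2 reaches only a limit, > 100000 nM, which is a limit and not a number, as the limit of > 100000 nM in this assay, at which 1 of the 3 values shown sits, records.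

Compound 4 `N#Cc1ccc(Nc2nc(Oc3ccnc4ccccc34)nc(N3CCN(Cc4ccccc4)CC3)n2)cc1C(F)(F)F` differs from compound 3 by benzyl in place of 3-(trifluoromethyl)phenyl on an amine nitrogen in a ring. Within the data shown here, only the step from compound 1 to compound 3 bears on this change, and it shows that an exchange of the group on this ring nitrogen moves the number by a modest amount. The limit seen for compound 2, whose nitrogen carries a benzylic group, suggests that the direction for compound 4 is upward. Compound 4 is therefore expected to show a step of a 2.3-fold higher number from compound 3 to compound 4 (0.37 log units; beyond the scatter), beyond the scatter, in this assay. The estimate for compound 4 is 90000 nM, with a range from 35000 nM to 250000 nM.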

Compound 4, concentration for 50% growth inhibition: > 100000 nM
Compound 4: no number, only a limit; the forecaster's own chance of this, stated with the estimate: 40%; middle value at least 1.1-fold (0.04 log units) away from the limit.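

With benzyl on the ring nitrogen, compound 4 reaches only a limit of the assay and not a number, as compound 2 does: the limit of > 100000 nM in this assay, at which 2 of the 4 values shown sit. Benzyl in place of 3-(trifluoromethyl)phenyl gives an at least 2.5-fold higher number from compound 3 to compound 4 (0.41 log units; beyond the scatter), so this exchange costs at least as much as the change seen earlier at this position, while benzyl in place of pyridin-2-yl gives an at least 1.1-fold higher number from compound 1 to compound 4 (0.06 log units; that floor lies within the scatter), a floor that on its own separates nothing. Across the four compounds, the two with a saturated chain carbon on the ring nitrogen, compound 2 and compound 4, sit at the limit, the two with an aromatic ring there, compound 1 and compound 3, give numbers, and none of the four goes against this, though the step between the two limits cannot be read.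

From the compounds shown here alone, how far the true values of compound 2 and compound 4 lie from the limit remains unknown, so the full size of the benzyl exchange stays open. Also open, going by these compounds, is whether a longer chain between the ring nitrogen and the phenyl ring, or an amine or a carboxylic acid on that phenyl ring, would return a measurable number in this assay.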